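This account rests on a few compounds, and the source may have more. Where it says the series, first, only, none or still open, it means among the compounds named here.

- Compound 1 `C/C(=N/NC(=S)Nc1ccccc1)c1ccccn1`: 1.4 nM
- Compound 2 `C/C(=N/NC(=S)Nc1ccc(Cl)cc1)c1ccccn1`: 1.7 nM

In a functional assay on U-87MG ATCC cells (Homo sapiens) for cytotoxicity, read by MTT assay, with a stated time of 48 h (on this read-out higher numbers stand for weaker inhibition and lower numbers for stronger inhibition), compound 2 gives 1.7 nM, which lies within the scatter of compound 1. Compound 3 `C/C(=N/NC(=S)Nc1ccc([N+](=O)[O-])cc1)c1ccccn1` has nitro in place of chloro on an aromatic carbon, para to a large group: nitro in place of chloro on an aromatic carbon. For the measured compounds named here, the one measured step that bears on this is a 1.2-fold higher number from compound 1 to compound 2 (0.08 log units; within the scatter), where chloro replaced hydrogen. Going by the values given here, with only that small step as a guide, no change beyond the scatter is expected in this assay, although nitro itself is untested. The expected step is a 1.2-fold higher number from compound 2 to compound 3 (0.07 log units; within the scatter). For compound 3 the estimated value is 2 nM, with an expected range of 0.7 nM to 7 nM.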

Compound 3, half-maximal inhibitory concentration: 160 nM
Compound 3: middle estimate off by 80-fold (1.90 log units), on the low side; measured number above the stated range.
By their numbers in this assay, from the lowest: compounds 1 and 2 (each within the scatter of the next); then compound 3.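

In this assay this aromatic carbon, para to a large group, is sensitive to what it carries: nitro gives a 94-fold higher number from compound 2 to compound 3 (1.97 log units; beyond the scatter) and a 110-fold higher number from compound 1 to compound 3 (2.06 log units; beyond the scatter) and so weakens inhibition well beyond the scatter. Hydrogen and chloro had shown no such sensitivity, so the harmless chloro change gave no warning of this loss. Nothing available here explains it. Going by these compounds, whether the loss belongs to nitro alone stays open, and so does what an amine or a methoxy group would give at this place.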